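Straightening the Ester-Bearing Chain on the Sulfur

This account rests on a few compounds, and the source may have more. Where it says the series, first, only, none or still open, it means among the compounds named here.

Measured so far:
compound 1 `CCOC(=O)CSc1nc2cc(-n3nc(C(C)(C)C)sc3=O)c(Cl)cc2s1` — 5820 nM
compound 2 `CCOC(=O)C(C)(C)Sc1nc2cc(-n3nc(C(C)(C)C)sc3=O)c(Cl)cc2s1` — 34400 nM

In an assay on isolated protein for inhibition of protoporphyrinogen oxidase (Homo sapiens), read by capillary electrophoresis (a higher number here means a weaker inhibitor, a lower number a stronger inhibitor), compound 1 gives 5820 nM. Within the data shown here, compound 2 gives 34400 nM, the higher of the two numbers, its only neighbour being compound 1 through the step of a 5.9-fold higher number from compound 1 to compound 2 (0.77 log units; beyond the scatter). Compound 3 `CCOC(=O)CCSc1nc2cc(-n3nc(C(C)(C)C)sc3=O)c(Cl)cc2s1` differs from compound 2 by 2-(ethoxycarbonyl)ethyl in place of 1-(ethoxycarbonyl)-1-methylethyl on a sulfur. Among the measured compounds shown here, the one measured step bears on this directly: replacing (ethoxycarbonyl)methyl with 1-(ethoxycarbonyl)-1-methylethyl gave a 5.9-fold higher number from compound 1 to compound 2 (0.77 log units; beyond the scatter), a rise beyond the scatter. Going back to a chain without the two methyls, now one carbon longer, is expected to lower the number again, roughly a 4.3-fold lower number from compound 2 to compound 3 (0.63 log units; beyond the scatter). Compound 3 is therefore estimated at 8000 nM, within 3000 nM to 25000 nM.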

Compound 3, inhibition constant: 1280 nM
The estimate for compound 3 lay 6.3-fold (0.80 log units) above the measured number, and the stated range ends above it.
By their numbers in this assay, from the lowest: compound 3; then compound 1; then compound 2.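

In this assay, a 4.5-fold lower number from compound 1 to compound 3 (0.66 log units; beyond the scatter), so the chain on the sulfur can grow beyond (ethoxycarbonyl)methyl with a lower number, not merely a retained one. Set against the two methyls of compound 2, the 2-(ethoxycarbonyl)ethyl chain gives a much larger change, a 27-fold lower number from compound 2 to compound 3 (1.43 log units; beyond the scatter), and compound 3 has the lowest number of the three. No data here explain why this chain gives the lowest number. As far as these compounds go, whether a longer chain, such as 3-(ethoxycarbonyl)propyl, lowers the number further remains open. So does whether a carboxylic acid or an amide could replace the ethyl ester.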